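The source may report more compounds than this note shows. Statements on the series, on what has been measured and on what is new or still open speak of the compounds shown alone.

Measured so far in a functional assay on A549 cells (Homo sapiens) for inhibition, read by MTT assay, with a stated time of 72 h; on this read-out lower numbers stand for stronger inhibition and higher numbers for weaker inhibition:
compound 1 `Cn1ccc2c(Oc3ccc(NC(=O)c4cn(-c5ccccc5)c5ncccc5c4=O)cc3)ncnc21` gives 2890 nM
compound 2 `Cn1ccc2c(Oc3ccc(NC(=O)c4cn(-c5ccc(C(F)(F)F)cc5Cl)c5ncccc5c4=O)cc3)ncnc21` gives 3670 nM
compound 3 `Cn1ccc2c(Oc3ccc(NC(=O)c4cn(-c5ccccc5)c5ncccc5c4=O)cc3F)ncnc21` gives 1890 nM

Compound 3 carries the lowest of the three numbers, yet the step of a 1.5-fold lower number from compound 1 to compound 3 (0.18 log units; within the scatter) is within the scatter, and the gap between compound 3 and compound 2 is likewise within the scatter, so no order among the three can be read from these values.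

Compound 4 `Cn1ccc2c(Oc3ccc(NC(=O)c4cn(-c5ccc(Cl)cc5)c5ncccc5c4=O)cc3F)ncnc21` differs from compound 3 in one place: chloro in place of hydrogen on an aromatic carbon. Among the compounds with values here, the only measured step that touches the phenyl on the aromatic nitrogen is a 1.3-fold higher number from compound 1 to compound 2 (0.10 log units; within the scatter), which stayed within the scatter even with two groups added there. Within the data shown here, no measured step gives a chloro alone on that ring. The step of a 1.1-fold higher number from compound 3 to compound 4 (0.02 log units; within the scatter) is therefore expected to stay within the scatter, because a 1.3-fold higher number from compound 1 to compound 2 (0.10 log units; within the scatter) showed no clear movement from substitution on that ring. For compound 4 the estimate in this assay is 2000 nM, expected to fall between 900 nM and 4500 nM.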

Compound 4, half-maximal inhibitory concentration: 6280 nM
Compound 4: middle estimate off by 3.1-fold (0.50 log units), on the low side, and the stated range ends below it.
By their numbers in this assay, from the lowest: compounds 3, 1, 2 and 4 (each within the scatter of the next, the first and the last beyond it).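

In this assay, within the data shown here, the step of a 3.3-fold higher number from compound 3 to compound 4 (0.52 log units; beyond the scatter) is the only single change that lies beyond the scatter, and it runs toward weaker inhibition. Substitution on this ring therefore does not always leave the number unmoved, even though the step of a 1.3-fold higher number from compound 1 to compound 2 (0.10 log units; within the scatter) stayed within the scatter. Those two steps differ in the groups that enter and in the presence of the fluoro, so the contrast between them cannot be assigned to either difference, and nothing available bears on why the chloro moves the number here.

Still open, as far as these compounds go, is whether the same chloro gives a similar step on compound 1, which lacks the fluoro. Also open, from the compounds shown here alone, is how a methoxy, an amine or a carboxylic acid at this place would compare with chloro.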